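Swapping a diethylamino tail for an imidazolyl ring

This account rests on a few compounds, and the source may have more. Where it says the series, first, only, none or still open, it means among the compounds named here.

Measured so far:
- compound 1, `COc1ccc(S(=O)(=O)N2CC(C(=O)NC3CCN(C)CC3)c3ccccc32)c2ccccc12`: 25.1 nM
- compound 2, `COc1ccc(S(=O)(=O)N2CC(C(=O)N3CC(N)C3)c3ccccc32)c2ccccc12`: 158 nM
- compound 3, `CCN(CC)CCCNC(=O)C1CN(S(=O)(=O)c2ccc(OC)c3ccccc23)c2ccccc21`: 79.4 nM

All three share one core and differ only in the group attached to the carbonyl. In a functional assay on CHO cells for antagonist activity at 5-hydroxytryptamine receptor 6 (Homo sapiens), read by FLIPR (a higher number here means a weaker inhibitor, a lower number a stronger inhibitor), compound 3 gives 79.4 nM, the second highest of the three numbers. The nearer of its two neighbours is reached by a 2.0-fold lower number from compound 2 to compound 3 (0.30 log units; within the scatter), and the further one by a 3.2-fold higher number from compound 1 to compound 3 (0.50 log units; beyond the scatter).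

Compound 4, `COc1ccc(S(=O)(=O)N2CC(C(=O)NCCCn3ccnc3)c3ccccc32)c2ccccc12`, has not yet been measured in this assay. It differs from compound 3 in one place: 1H-imidazol-1-yl in place of diethylamino on a saturated chain carbon, three bonds along the chain from an amide-type nitrogen. Within the data shown here, no measured pair shows this particular exchange, so the only guidance comes from the neighbouring steps. Those steps, a 3.2-fold higher number from compound 1 to compound 3 (0.50 log units; beyond the scatter) and a 6.3-fold higher number from compound 1 to compound 2 (0.80 log units; beyond the scatter), show that reshaping the group on the carbonyl shifts the number by modest amounts. A change of similar size is therefore expected here, most likely toward a somewhat higher number, with a 2.0-fold higher number from compound 3 to compound 4 (0.30 log units; within the scatter). Compound 4 is estimated at 160 nM in this assay, within a range from 40 nM to 630 nM.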

Compound 4, inhibition constant: 79.4 nM
Beside the measured number, compound 4's estimate is 2.0-fold (0.30 log units) above it; the range from low to high includes it.
By their numbers in this assay, from the lowest: compound 1; then compounds 3, 4 and 2 (each within the scatter of the next).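

In this assay, exchanging the diethylamino end of the 3-(diethylamino)propyl chain for 1H-imidazol-1-yl, a five-membered aromatic ring with 2 hetero atoms, gives no change at the digits printed from compound 3 to compound 4 (within the scatter). At this place on the chain, then, the two groups cannot be told apart by this read-out, even though one has a ring and the other has none, and the new compound sits where compound 3 sat relative to the others, with a 2.0-fold lower number from compound 2 to compound 4 (0.30 log units; within the scatter) and a 3.2-fold higher number from compound 1 to compound 4 (0.50 log units; beyond the scatter). Nothing available explains why these two groups read alike.

The compounds shown leave open whether a carboxylic acid or a primary amine at the end of the same chain would also read alike. Also open, going by these compounds, is whether a shorter or longer chain carrying 1H-imidazol-1-yl would match compound 4.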